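Trimming the 4-pentylphenyl group of compound 1

This account rests on a few compounds, and the source may have more. Where it says the series, first, only, none or still open, it means among the compounds named here.

For the measured compounds named here, in a functional assay on HeLa cells (Homo sapiens) for antiproliferative activity, read by MTT assay, with a stated time of 72 h (on this read-out lower numbers stand for stronger inhibition and higher numbers for weaker inhibition), compound 1 `CCCCCc1ccc(-c2cn(C[C@H](O)[C@H]3OC(=O)C(OCc4ccccc4)=C3OCc3ccccc3)nn2)cc1` gives 8390 nM, the only actual number available so far. Compound 2 `O=C1O/C(=C\Cn2cc(-c3cc(C(F)(F)F)cc(C(F)(F)F)c3)nn2)C(OCc2ccccc2)=C1OCc1ccccc1` is reported only as a limit, > 100000 nM. Compound 3 `O=C1O[C@H]([C@@H](O)Cn2cc(C3CC3)nn2)C(OCc2ccccc2)=C1OCc1ccccc1` keeps the core of compound 1 but carries cyclopropyl in place of 4-pentylphenyl on an aromatic carbon. Going by the values given here, no measured pair isolates this change, so the expectation rests on the structural swap alone. In this assay a clear loss of inhibition is expected, a step towards higher numbers and well beyond the usual scatter, starting from compound 1 at 8390 nM. The estimated change is a 6.0-fold higher number from compound 1 to compound 3 (0.78 log units; beyond the scatter). Compound 3 is expected at 50000 nM, with an estimated range from 15000 nM to 150000 nM, and the measurement may return only a limit.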

Compound 3, half-maximal inhibitory concentration: 26500 nM
Estimate against measurement, compound 3: 1.9-fold (0.28 log units) above; the range from low to high includes it.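

In this assay, this position on the five-membered aromatic ring now has its first measured step: cyclopropyl in place of 4-pentylphenyl gives a 3.2-fold higher number from compound 1 to compound 3 (0.50 log units; beyond the scatter). A group of 11 heavy atoms gives way to one of 3 at a modest cost, and compound 3 still returns an actual number, 26500 nM. Nothing at hand gives a reason for this step.

On these data alone, whether the difference follows the phenyl ring or the pentyl chain stays open, as a plain phenyl group or an open butyl chain at this carbon would each be a single change from compound 1. Also open, as far as these compounds go, is how an amine or a carboxylic acid on this carbon would read in this assay.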